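The source may hold more compounds than are shown below. What is called first, only, known or untested is meant among the compounds shown, and "the series" means these compounds.

Compound 1 `CC(C)=CCc1cc(C(=O)Nc2cc3ccc(OCCC4CCCCN4)c(C)c3oc2=O)ccc1O` is one of three close analogues that share a core and differ only in the amine carried on the chain from the aromatic oxygen. In a functional assay on SK-BR-3 cells (Homo sapiens) for antiproliferative activity (a higher number here means a weaker inhibitor, a lower number a stronger inhibitor), compound 1 gives 640 nM, the second highest of the three numbers. Compound 2 `CC(C)=CCc1cc(C(=O)Nc2cc3ccc(OCCCN4CCCC4)c(C)c3oc2=O)ccc1O` gives 720 nM, and compound 3 `CC(C)=CCc1cc(C(=O)Nc2cc3ccc(OCCCN(C)C(C)C)c(C)c3oc2=O)ccc1O` gives 570 nM. The steps among them are small: a 1.1-fold higher number from compound 1 to compound 2 (0.05 log units; within the scatter), a 1.1-fold lower number from compound 1 to compound 3 (0.05 log units; within the scatter) and a 1.3-fold lower number from compound 2 to compound 3 (0.10 log units; within the scatter), none of them reaching beyond the scatter.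

Compound 4 `CC(C)=CCc1cc(C(=O)Nc2cc3ccc(OCCCN(C(C)C)C(C)C)c(C)c3oc2=O)ccc1O` has not yet been measured. It differs from compound 1 in one place: (diisopropylamino)methyl in place of piperidin-2-yl on a saturated chain carbon, two bonds along the chain from an oxygen on an aromatic ring. Among the compounds with values here, the closest precedent is the step from compound 1 to compound 3, where the ring likewise gives way to an open (isopropyl(methyl)amino)methyl group, and the step to compound 2, where a (pyrrolidin-1-yl)methyl group replaces it; both stayed within the scatter. On this basis compound 4 is expected to sit with the others, with a step of a 1.0-fold lower number from compound 1 to compound 4 (0.01 log units; within the scatter) that is not expected to exceed the scatter. The estimate for compound 4 is 620 nM, with a likely range from 300 nM to 1300 nM.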

Compound 4, half-maximal inhibitory concentration: 1600 nM
Compound 4: middle estimate off by 2.6-fold (0.41 log units), on the low side; the whole stated range lies below it.
By their numbers in this assay, from the lowest: compounds 3, 1 and 2 (each within the scatter of the next); then compound 4.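

In this assay, within the data shown here, the amine on this chain had so far made no difference beyond the scatter, and the diisopropylamino group is the first to do so, with a 2.8-fold higher number from compound 3 to compound 4 (0.45 log units; beyond the scatter) and with a 2.2-fold higher number from compound 2 to compound 4 (0.35 log units; beyond the scatter) as well as a 2.5-fold higher number from compound 1 to compound 4 (0.40 log units; beyond the scatter) all in the same direction. The step from compound 3 is the narrowest change of the three, isopropyl in place of methyl on an amine nitrogen, so the tolerance seen across the piperidin-2-yl, pyrrolidin-1-yl and isopropyl(methyl)amino compounds does not extend to every amine at this place. Nothing measured here accounts for the weaker number of compound 4, and its cause remains unknown.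

The compounds shown leave open whether ethyl in place of methyl on that amine nitrogen would already raise the number, or whether the rise begins only with a second isopropyl group. They also leave open whether a morpholine or piperazine ring would sit with compounds 1, 2 and 3, and whether a shorter chain, such as 2-(diisopropylamino)ethoxy in place of 3-(diisopropylamino)propoxy, would keep the same step.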